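Chlorophenyl and hydroxyphenyl analogues at the human adenosine A3 receptor

The compounds below may be only part of what the source reports. "The series", "measured", "known", "first", "only" and "open" are said of these compounds alone.

Measured so far:
compound 1 `CN1CCN(c2nc(-c3cccc(Cl)c3)nc3[nH]cnc23)CC1` — 100 nM
compound 2 `CN1CCN(c2nc(-c3cccc(O)c3)nc3[nH]cnc23)CC1` — 501 nM

In an assay on cells for displacement of a labelled ligand from adenosine receptor A3 (Homo sapiens), read by scintillation counting and radioligand binding, with a stated time of 180 min (a lower number here means a stronger inhibitor, a higher number a weaker inhibitor), compound 1 gives 100 nM and compound 2 gives 501 nM. Among the compounds with values here, compound 2 therefore stands at the higher of the two numbers; the one measured step, a 5.0-fold higher number from compound 1 to compound 2 (0.70 log units; beyond the scatter), separates it from compound 1.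

Compound 3 `CN1CCN(c2nc(-c3ccc(Cl)cc3)nc3[nH]cnc23)CC1` is not yet measured. Its change from compound 2 is 4-chlorophenyl in place of 3-hydroxyphenyl on an aromatic carbon. The step from compound 1 to compound 2 bears on this directly in reverse: swapping hydroxy back for chloro on that ring should undo most of the loss. Within the data shown here, compound 1 also carries a chlorophenyl group, though not 4-chlorophenyl, so the arrangement differs and no measured step covers that part.

For compound 3 the expected outcome in this assay is a lower number than compound 2, roughly a 3.3-fold lower number from compound 2 to compound 3 (0.52 log units; beyond the scatter). The estimate for compound 3 is 150 nM, within 40 nM to 600 nM.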

Compound 3, inhibition constant: 39.8 nM
Beside the measured number, compound 3's estimate is 3.8-fold (0.58 log units) above it; measured number outside the range, below it.
By their numbers in this assay, from the lowest: compound 3; then compound 1; then compound 2.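

In this assay, keeping the chloro group and changing only its place on the phenyl ring gives a 2.5-fold lower number from compound 1 to compound 3 (0.40 log units; beyond the scatter), so the substitution position matters, which compounds 1 and 2 alone could not show. The change from 3-hydroxyphenyl to 4-chlorophenyl gives a 13-fold lower number from compound 2 to compound 3 (1.10 log units; beyond the scatter), a large step that alters both the group and its place on the ring. Nothing measured here gives a reason for the order of these compounds.

The compounds shown do not separate the effect of place from that of group for hydroxy, as a 4-hydroxyphenyl analogue would. Going by these compounds, it also remains open whether the gain extends to other groups at this place on the ring, such as 4-fluorophenyl, 4-methoxyphenyl or 4-aminophenyl.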